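Mirror-image stereocentre on a tetrabromo core: antiproliferative read-out

The source may hold more compounds than are shown below. What is called first, only, known or untested is meant among the compounds shown, and "the series" means these compounds.

Compound 1, `OC(CCn1nc2c(Br)c(Br)c(Br)c(Br)c2n1)c1cccc(Br)c1`: 123%
Compound 2, `C[C@@H](O)CCn1nc2c(Br)c(Br)c(Br)c(Br)c2n1`: 81%

Two compounds share a tetrabrominated core carrying a hydroxy-bearing chain, and both have been tested in a functional assay on CCRF-CEM cells (Homo sapiens) for antiproliferative activity, read by MTT assay, with a stated time of 24 h, tested at 25 uM; a lower number here means a stronger effect, a higher number a weaker effect of the compound at the concentration tested. Compound 1, `OC(CCn1nc2c(Br)c(Br)c(Br)c(Br)c2n1)c1cccc(Br)c1`, gives 123% in this assay. Compound 2, `C[C@@H](O)CCn1nc2c(Br)c(Br)c(Br)c(Br)c2n1`, gives 81% in this assay, the lower of the two numbers; its gap to compound 1 lies beyond the usual scatter, so compound 2 shows the stronger effect of the pair at this concentration.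

The step under consideration leads from compound 2 to compound 3, `C[C@H](O)CCn1nc2c(Br)c(Br)c(Br)c(Br)c2n1`. The two compounds have the same atoms and bonds and differ only in configuration as drawn: the two compounds have the same atoms and bonds and differ only in configuration as drawn: 1 of 1 stereo elements differ; a stereocentre at a saturated chain carbon is drawn R in compound 2 and S in compound 3

Among the measured compounds shown here, no step between measured compounds is available that changes only a stereocentre, so there is no measured precedent for its size. Because compound 2 gives 81% in this assay and nothing in the data points to a direction for a change of configuration alone, a step of a number 1 percentage points higher from compound 2 to compound 3 (within the scatter) is expected, that is, none beyond the scatter. Compound 3 is therefore estimated at 82% in this assay, within a range from 55% to 110%.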

Compound 3, a percentage reported as activity, at one concentration (the size of the read-out at that concentration, not a potency): 112%
Compound 3: the middle estimate sits 30 percentage points below what was measured, outside the stated range (above it).
By their numbers in this assay, from the lowest: compound 2; then compound 3; then compound 1.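

Among the compounds shown here, the pair shows that this saturated chain carbon is sensitive to configuration, something the earlier compounds could not reveal, since no measured step had isolated a stereocentre. In this assay, redrawing the stereocentre from R to S gives a number 31 percentage points higher from compound 2 to compound 3 (beyond the scatter), so the R form, compound 2, has the stronger effect at this concentration, and the mirror-image change alone is enough to move the read-out beyond the scatter. The gap can be assigned to the stereocentre because nothing else separates the two structures: the fact that compounds 2 and 3 differ only in the configuration as drawn

The compounds shown leave open whether this preference for the R form persists when an amine or a carboxylic acid takes the place of the hydroxy group, or when the hydroxy group sits on a longer chain. They also leave open whether the configuration would make the effect stronger or weaker at other concentrations, and they give no indication of why the mirror-image forms differ, as the read-out comes from a single concentration in whole cells.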